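A few compounds are considered here, and "the series" means these few. Any claim that something is new, unique, unknown or untested is made for them only; others in the source may bear on it.

The series is assessed in an assay on HEK293 cells for binding affinity to prostaglandin E2 receptor EP2 subtype (Homo sapiens); a lower number here means a stronger inhibitor, a higher number a weaker inhibitor. Compound 1, `O=C(O)/C=C/c1ccccc1-c1ccc(Cl)c(Cl)c1`, gives 7500 nM in this assay. Compound 2, `O=C(O)/C=C/c1ccccc1-c1cccc(-c2ccccc2OCc2ccccc2)c1`, gives 830 nM, the lowest of the three numbers in hand. Compound 3, `O=C(O)CCc1ccccc1-c1ccc(-c2ccccc2OCc2ccccc2)s1`, gives 4100 nM. Compound 2 thus stands below compound 3 and below compound 1, and both gaps are beyond the usual scatter.

The step of interest leads from compound 2 to compound 4, `CC(Cc1ccccc1-c1cccc(-c2ccccc2OCc2ccccc2)c1)C(=O)O`. The change is 2-carboxypropyl in place of 2-carboxyethenyl on an aromatic carbon. Compound 4 carries the 2-carboxypropyl in place of the 2-carboxyethenyl; the rest of the molecule is kept. Within the data shown here, no measured pair in this set differs in one place only, so no counted step guides the expectation directly. Compound 3 also carries a saturated acid chain and gives 4100 nM, but compound 3 differs from compound 2 in more than one place, so only the two values themselves can be compared.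

Compound 4 is expected to come out somewhat weaker in this assay, with a step of a 1.9-fold higher number from compound 2 to compound 4 (0.29 log units; within the scatter) that is estimated to lie near the edge of the scatter. The estimate for compound 4 is 1600 nM, in a range from 500 nM to 5000 nM.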

Compound 4, inhibition constant: 3600 nM
Beside the measured number, compound 4's estimate is 2.3-fold (0.35 log units) below it, and the stated range covers the measured number.
By their numbers in this assay, from the lowest: compound 2; then compounds 4, 3 and 1 (each within the scatter of the next, the first and the last beyond it).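

Among these compounds, compound 2 and compound 4 form the first pair here that differs in one place only, so this is the first direct reading of this position in this assay. Putting 2-carboxypropyl in place of 2-carboxyethenyl on this aromatic carbon, ortho to a large group, gives a 4.3-fold higher number from compound 2 to compound 4 (0.64 log units; beyond the scatter), which shows that the number responds to the make-up of the acid-bearing chain even with the acid itself kept. The swap removes the double bond of the chain and adds a branch in a single step, so the result cannot say which of the two accounts for the rise, and no supporting measurement on the cause of the step is available.

The compounds shown leave open how an unbranched 2-carboxyethyl chain would read on the core of compound 2, which would separate the loss of the double bond from the gain of the branch. They also leave open whether a tetrazole or a primary amide could stand in for the carboxylic acid at this position.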